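Shortening an Ethyl Group to Methyl

The compounds below may be only part of what the source reports. "The series", "measured", "known", "first", "only" and "open" are said of these compounds alone.

Of the compounds shown here, two have been measured so far. Compound 1 `Nc1ccccc1NC(=O)c1ccc(CSC(=S)N2CCc3cc(Cl)ccc32)cc1` in a functional assay on A-375 cells (Homo sapiens) for antiproliferative activity, read by CCK-8 assay, with a stated time of 72 h, tested at 8 uM (on this read-out higher numbers stand for a stronger effect at the one concentration tested and lower numbers for a weaker effect), gives 82.3%. Compound 2 `CCN(Cc1ccncc1)C(=S)SCc1ccc(C(=O)Nc2ccccc2N)cc1`, which carries ethyl((pyridin-4-yl)methyl)amino in place of 5-chloro-2,3-dihydro-1H-indol-1-yl on a thiocarbonyl carbon, gives 86.2% in this assay. The step of a number 3.9 percentage points higher from compound 1 to compound 2 (within the scatter) lies within the scatter, so compound 2 and compound 1 cannot be told apart on these numbers, even though compound 2 holds the higher of the two.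

Compound 3 `CN(Cc1ccncc1)C(=S)SCc1ccc(C(=O)Nc2ccccc2N)cc1` differs from compound 2 by a small change: hydrogen in place of methyl on a saturated chain carbon bound to an amide-type nitrogen, that is, ethyl to methyl. For the measured compounds named here, the one measured step, a swap of the whole amine part, moved the read-out hardly at all, and no step of the present kind has been measured. Going by the values given here, with that step as the only guide, a change of a single carbon is expected to leave this assay about where it is, so the expected step of a number 2.2 percentage points lower from compound 2 to compound 3 (within the scatter) is within the scatter. Compound 3 is therefore estimated at 84% in this assay, expected between 72% and 94%.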

Compound 3, a percentage reported as inhibition, at one concentration (the size of the read-out at that concentration, not a potency): 86.1%
Estimate against measurement, compound 3: 2.1 percentage points below; the range from low to high includes it.
By their numbers in this assay, from the lowest: compounds 1, 3 and 2 (each within the scatter of the next).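

In this assay the terminal carbon of the ethyl group can go: the change from ethyl((pyridin-4-yl)methyl)amino to methyl((pyridin-4-yl)methyl)amino gives a number 0.1 percentage points lower from compound 2 to compound 3 (within the scatter) and so leaves the read-out indistinguishable from that of the ethyl compound. For the compounds shown here, this is the first direct look at this place on the chain, and at this single concentration the read-out does not depend on that one carbon. The methyl compound also stays level with the chloro-substituted compound, with a number 3.8 percentage points higher from compound 1 to compound 3 (within the scatter) for the exchange of 5-chloro-2,3-dihydro-1H-indol-1-yl for methyl((pyridin-4-yl)methyl)amino, so neither amine part can yet be set apart from the others. No measurement at hand offers an explanation for this flat result.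

The compounds shown leave open whether a longer chain such as propyl or butyl, or a chain ending in a hydroxyl group or a carboxylic acid, would hold the read-out at this place on the nitrogen. They also leave open whether compounds this close at one concentration would separate in a full measurement of potency.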